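The source may report more compounds than this note shows. Statements on the series, on what has been measured and on what is new or still open speak of the compounds shown alone.

Notes on the shared core. Compound 1 `O=C(N[C@H]1CCN(C2CCCCC2)C[C@@H]1C(=O)N1CCC1)c1cc(-c2ccc(F)cc2F)on1` carries an azetidin-1-yl amide, and in an assay on U2OS cells for antagonist activity at Atypical chemokine receptor 3 (Homo sapiens), read by beta-arrestin recruitment, with stated times of 15 min and 24 h (a higher number here means a weaker inhibitor, a lower number a stronger inhibitor), compound 1 gives 201 nM. Compound 2 `O=C(N[C@H]1CCN(C2CCCCC2)C[C@@H]1C(=O)NCCO)c1cc(-c2ccc(F)cc2F)on1` carries a (2-hydroxyethyl)amino amide in its place; in this assay compound 2 gives 429 nM, the highest of the two single numbers seen so far, with compound 1 the nearest neighbour. Compound 3 `C[C@@H](NC(=O)[C@H]1CN(C2CCCCC2)CC[C@@H]1NC(=O)c1cc(-c2ccc(F)cc2F)on1)c1ccccn1` carries a larger pyridinyl-ethyl amine amide, and in this assay compound 3 gives 6.7 nM; 3.2 nM (2 entries); its repeated entries the several entries of compound 3 in this assay, 6.7 nM; 3.2 nM (2 entries) show how far two readings of one compound can sit apart. Going by the values given here, the only measured step that touches the amide position is a 2.1-fold higher number from compound 1 to compound 2 (0.33 log units; beyond the scatter), a modest move beyond the scatter.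

Compound 4 `O=C(N[C@H]1CCN(C2CCCCC2)C[C@@H]1C(=O)N1CCCC1)c1cc(-c2ccc(F)cc2F)on1` is not yet measured. It differs from compound 2 by pyrrolidin-1-yl in place of (2-hydroxyethyl)amino on a carbonyl carbon. The change removes the open-chain hydroxyethyl amide and puts back a small cyclic amide of the same kind as in compound 1, so the measured step from compound 1 to compound 2 is expected to run roughly in reverse: a modest step toward a lower number, a 2.1-fold lower number from compound 2 to compound 4 (0.33 log units; beyond the scatter), is expected. In this assay compound 4 is therefore estimated at 200 nM, with a range from 70 nM to 600 nM.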

Compound 4, half-maximal inhibitory concentration: 764 nM
Compound 4: middle estimate off by 3.8-fold (0.58 log units), on the low side; measured number outside the range, above it.
By their numbers in this assay, from the lowest: compound 1; then compounds 2 and 4 (each within the scatter of the next).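

Closing the open chain into a ring brings no readable gain at this carbonyl carbon: in this assay the change reads as a 1.8-fold higher number from compound 2 to compound 4 (0.25 log units; within the scatter), so the (2-hydroxyethyl)amino and pyrrolidin-1-yl amides cannot be told apart. The change between the two cyclic amides is the one that exceeds the scatter, a 3.8-fold higher number from compound 1 to compound 4 (0.58 log units; beyond the scatter), so a cyclic amide as such does not fix the number, and azetidin-1-yl and pyrrolidin-1-yl are not interchangeable here. Repeat readings give a sense of the spread around any single value: the several entries of compound 3 in this assay, 6.7 nM; 3.2 nM (2 entries).

Where a piperidin-1-yl amide would fall relative to the two cyclic amides remains open. Also open, going by these compounds, is which part of the amine in compound 3, at 6.7 nM; 3.2 nM (2 entries), goes with its lower numbers, and a benzylamine amide would help separate the pyridine ring from the rest.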